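5α-Reductase binding: piperidine amide series, aryl ring changes

The source may hold more compounds than are shown below. What is called first, only, known or untested is meant among the compounds shown, and "the series" means these compounds.

Measured so far:
compound 1, `O=C(O)c1ccc(C=C2CCN(C(=O)C(C3CCCCC3)C3CCCCC3)CC2)cc1`, 46%
compound 2, `COc1cc(C(=O)O)ccc1C=C1CCN(C(=O)C(C2CCCCC2)C2CCCCC2)CC1`, 5%

For the measured compounds named here, compound 2 has the lower of the two numbers in an assay for inhibition of 3-oxo-5-alpha-steroid 4-dehydrogenase 1 (Homo sapiens), tested at 10 uM; a lower number here means less inhibition, a higher number more inhibition at the concentration tested (going by the name of the read-out); its nearest neighbour is compound 1, and the one measured step, a number 41 percentage points lower from compound 1 to compound 2 (beyond the scatter), is large and beyond the scatter.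

Compound 3, `O=C(O)Cc1ccc(C=C2CCN(C(=O)C(C3CCCCC3)C3CCCCC3)CC2)c(F)c1`, is not yet measured. It differs from compound 2 by 4-(carboxymethyl)-2-fluorophenyl in place of 4-carboxy-2-methoxyphenyl on a double-bonded chain carbon bound to a double-bonded ring carbon. Going by the values given here, no measured step bears on this exchange directly: the only step in hand concerns methoxy against hydrogen, and compound 3 carries neither a methoxy nor the carboxy of compounds 1 and 2. Among the compounds with values here, since compound 2 sits at the low end, and removal of the methoxy is the one change for which a large effect is known, an upward step is expected, a number 25 percentage points higher from compound 2 to compound 3 (beyond the scatter), but the carboxymethyl and fluorine are untested and widen the range. Compound 3 is estimated at 30%, between 5% and 60%.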

Compound 3, a percentage reported as inhibition, at one concentration (the size of the read-out at that concentration, not a potency): 4%
Compound 3: middle estimate off by 26 percentage points, on the high side; the measured number lies below the stated range.
By their numbers in this assay, from the lowest: compounds 3 and 2 (each within the scatter of the next); then compound 1.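

At the place on a double-bonded chain carbon bound to a double-bonded ring carbon, 4-(carboxymethyl)-2-fluorophenyl in place of 4-carboxyphenyl gives in this assay a number 42 percentage points lower from compound 1 to compound 3 (beyond the scatter), so a large drop is no longer tied to the methoxy alone. 4-(Carboxymethyl)-2-fluorophenyl in place of 4-carboxy-2-methoxyphenyl gives a number 1 percentage points lower from compound 2 to compound 3 (within the scatter), which leaves these two groups indistinguishable here and 4-carboxyphenyl as the only aryl group shown that stands clear of both. Nothing at hand explains these steps.

Fluorine and carboxymethyl change together in compound 3, so their separate contributions remain unresolved. Also open, from the compounds shown here alone, is how the series responds to a carboxyethyl chain or to an amine in place of the carboxylic acid on the aryl ring.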